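This account rests on a few compounds, and the source may have more. Where it says the series, first, only, none or still open, it means among the compounds named here.

Working notes on the series. Compound 1 `Cc1cc(Cl)ccc1NCC(=O)N[C@H]1CCOC1=O`, compound 2 `O=C(CNc1ccccc1F)N[C@H]1CCOC1=O` and compound 3 `C=CCc1ccc(OCCSC(=S)N[C@H]2CCOC2=O)c(OC)c1` share the same core. In a functional assay on PC-3 cells (Homo sapiens) for antiproliferative activity, read by MTT assay, with a stated time of 72 h (on this read-out lower numbers stand for stronger inhibition and higher numbers for weaker inhibition), compound 1 gives only a limit, > 64000 nM. Compound 2 likewise gives a limit in this assay, > 64000 nM. Compound 3 also reaches only a limit in this assay, > 64000 nM. Compound 2 thus sits at the limit of > 64000 nM in this assay, at which 3 of the 3 values shown sit, and nothing separates it from the other two. Compound 4 `O=C(CNc1ccccc1)N[C@H]1CCOC1=O` differs from compound 2 by hydrogen in place of fluoro on an aromatic carbon. Within the data shown here, no step between measured compounds is available, and no step beyond the scatter is expected in this assay in either direction. The estimate for compound 4 in this assay is 100000 nM, between 30000 nM and 300000 nM. The expected step is a step that the limit leaves unreadable from compound 2 to compound 4.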

Compound 4, half-maximal inhibitory concentration: > 64000 nM
Compound 4 was reported as a limit; the forecaster's own chance of this, stated with the estimate: 85%; the middle value is on the limit's open side.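

Compound 2 and compound 4 both stand only as limits in this assay, so no step can be read between them. The compounds shown leave open what hydrogen in place of fluoro does to activity, and which change to the shared core would give a measurable value: the limit of > 64000 nM in this assay, at which 4 of the 4 values shown sit.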